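This account rests on a few compounds, and the source may have more. Where it says the series, first, only, none or still open, it means among the compounds named here.

Measured in a functional assay on DU-145 cells (Homo sapiens) for antiproliferative activity, read by MTT assay, with a stated time of 72 h; a lower number here means a stronger inhibitor, a higher number a weaker inhibitor:
Compound 1 `Cc1ccc(N(C)S(=O)(=O)C2CC3OC2C(c2ccc(NC(=O)CCCCCCC(=O)O)cc2)=C3c2ccc(O)cc2)cc1`: > 100000 nM
Compound 2 `CCN(c1ccc(C)cc1)S(=O)(=O)C1CC2OC1C(c1ccc(NC(=O)CCCCCCC(=O)O)cc1)=C2c1ccc(O)cc1`: 53500 nM
Compound 3 `CCN(c1ccc(O)cc1)S(=O)(=O)C1CC2OC1C(c1ccc(NC(=O)CCCCCCC(=O)O)cc1)=C2c1ccc(O)cc1`: > 100000 nM

Compound 3 stands at > 100000 nM, which is a limit and not a number, so it shares (the limit of > 100000 nM in this assay, at which 2 of the 3 values shown sit). Compound 4 `CCN(c1ccccc1Br)S(=O)(=O)C1CC2OC1C(c1ccc(NC(=O)CCCCCCC(=O)O)cc1)=C2c1ccc(O)cc1` carries 2-bromophenyl in place of 4-hydroxyphenyl on a sulfonamide nitrogen.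

Among the compounds with values here, no measured step makes this exact change. The closest one is an at least 1.8-fold higher number from compound 2 to compound 3 (0.27 log units; that floor lies within the scatter), for hydroxy in place of methyl on an aromatic carbon. Also relevant is an at least 1.8-fold lower number from compound 1 to compound 2 (0.27 log units; that floor lies within the scatter), for methyl in place of hydrogen on a saturated chain carbon bound to a sulfonamide nitrogen. Both are floors within the scatter, so neither fixes a size.

Within the data shown here, compound 4 keeps the ethyl group on that nitrogen, as does compound 2 at 53500 nM, the one true number. A lower number is therefore expected, though the result may well stay at the limit. The expected step is an at least 2.0-fold lower number from compound 3 to compound 4 (0.30 log units; that floor lies within the scatter). For compound 4 the estimate is 50000 nM, with an expected range from 20000 nM to 120000 nM.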

Compound 4, half-maximal inhibitory concentration: 95300 nM
Compound 4: middle estimate off by 1.9-fold (0.28 log units), on the low side; low and high end bracket the measured number.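

In this assay, 2-bromophenyl on the sulfonamide nitrogen gives compound 4 a true number, which 4-hydroxyphenyl at this place did not give compound 3, yet the step itself reads only as an at least 1.0-fold lower number from compound 3 to compound 4 (0.02 log units; that floor lies within the scatter), and the change on the sulfonyl sulfur reads only as an at least 1.0-fold lower number from compound 1 to compound 4 (0.02 log units; that floor lies within the scatter). Replacing 4-methylphenyl with 2-bromophenyl gives a 1.8-fold higher number from compound 2 to compound 4 (0.25 log units; within the scatter), so compound 2 and compound 4 cannot be told apart, even though the two groups differ in what they carry and where. Compound 1 and compound 3 remain limits and not numbers: the limit of > 100000 nM in this assay, at which 2 of the 4 values shown sit.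

The compounds shown do not separate the effect of bromine from that of its place on the ring, which 4-bromophenyl could address. Going by these compounds, whether 4-aminophenyl or a pyridine ring on this nitrogen would give a number beyond the scatter from compound 2 also stays open.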